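An Expected Small Step from Compound 3 to Compound 4

The source may report more compounds than this note shows. Statements on the series, on what has been measured and on what is new or still open speak of the compounds shown alone.

In a functional assay on HCT-116 cells (Homo sapiens) for antiproliferative activity, read by MTT assay, with a stated time of 72 h (a higher number here means a weaker inhibitor, a lower number a stronger inhibitor), compound 1 `O=C(CCc1cccc2c1B(O)OC2)Nc1ccccc1` gives 350 nM and compound 2 `CC(C)c1cccc(NC(=O)CCc2cccc3c2B(O)OC3)c1` gives 1600 nM, while compound 3 `COc1cc(OC)cc(-c2cccc(NC(=O)CCc3cccc4c3B(O)OC4)c2)c1` gives 53 nM as the lowest number of the three. Compound 4 `CSc1cccc(-c2cccc(NC(=O)CCc3cccc4c3B(O)OC4)c2)c1` carries 3-(methylsulfanyl)phenyl in place of 3,5-dimethoxyphenyl (3-(methylsulfanyl)phenyl in place of 3,5-dimethoxyphenyl on an aromatic carbon). Going by the values given here, two measured steps bear on this place: a 6.6-fold lower number from compound 1 to compound 3 (0.82 log units; beyond the scatter) when 3,5-dimethoxyphenyl replaces hydrogen, and a 30-fold lower number from compound 2 to compound 3 (1.48 log units; beyond the scatter) when it replaces isopropyl. Neither step swaps one substituted phenyl for another. Compound 4 keeps the six-membered aromatic ring, so in this assay no step beyond the scatter is expected, with a slight lean towards a higher number. The expected change is a 1.3-fold higher number from compound 3 to compound 4 (0.12 log units; within the scatter) overall. For compound 4 the estimate is 70 nM within an expected range from 25 nM to 200 nM here.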

Compound 4, half-maximal inhibitory concentration: 110 nM
The estimate for compound 4 lay 1.6-fold (0.20 log units) below the measured number; the measured number falls inside the stated range.
By their numbers in this assay, from the lowest: compound 3; then compound 4; then compound 1; then compound 2.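

Exchanging one substituted phenyl for another at this position is not neutral: in this assay the change gives a 2.1-fold higher number from compound 3 to compound 4 (0.32 log units; beyond the scatter), so the groups on the added ring matter as well as the ring itself. Compound 4 nevertheless keeps a clear lead over the simpler compounds, with a 3.2-fold lower number from compound 1 to compound 4 (0.50 log units; beyond the scatter) and a 15-fold lower number from compound 2 to compound 4 (1.16 log units; beyond the scatter). Nothing available here explains the difference between the two phenyl groups. Still open, on these data alone, is how an amine or a carboxylic acid on the added phenyl ring would fare in this assay.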